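Methyl to cyclopropyl on the core of compound 1

The source may hold more compounds than are shown below. What is called first, only, known or untested is meant among the compounds shown, and "the series" means these compounds.

Measured compounds:
- compound 1 `Cc1cnc(Nc2ccc(C(=O)Nc3c(C)cccc3C)cc2)nc1-c1ccc(OC(F)(F)F)cc1`: 1.3 nM
- compound 2 `Cc1cnc(Nc2ccc(C(=O)Nc3c(C)cccc3C)cc2)nc1-c1ccc(F)cc1`: 2.2 nM
- compound 3 `Cc1cnc(Nc2ccc(C(=O)Nc3c(C)cccc3C)cc2)nc1-c1cnn(C)c1`: 10.6 nM

All three values come from an assay on NIH3T3 cells for inhibition of Sonic hedgehog protein (Mus musculus), read by a luciferase reporter, with a stated time of 48 h; on this read-out higher numbers stand for weaker inhibition and lower numbers for stronger inhibition. Compound 1 holds the lowest number of the three; compound 2 sits nearest to it, the step of a 1.7-fold higher number from compound 1 to compound 2 (0.23 log units; within the scatter) lying within the scatter, so no order between compound 1 and compound 2 can be read from these two numbers. Compound 3 stands furthest, the step of an 8.2-fold higher number from compound 1 to compound 3 (0.91 log units; beyond the scatter) being beyond the scatter, and likewise a 4.8-fold higher number from compound 2 to compound 3 (0.68 log units; beyond the scatter).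

Compound 4 `Cc1cccc(C)c1NC(=O)c1ccc(Nc2ncc(C3CC3)c(-c3ccc(OC(F)(F)F)cc3)n2)cc1` has not yet been measured in this assay. The change from compound 1 is cyclopropyl in place of methyl on an aromatic carbon. Every measured step in this set concerns the aryl group on the shared core, the one carrying trifluoromethoxy, fluoro or the 1-methyl-1H-pyrazol-4-yl ring; none touches the methyl that leaves here. Among the compounds with values here, there is therefore no step that bears on the methyl-to-cyclopropyl exchange, and the expectation has to rest on the absence of any contrary sign. The step of a 1.2-fold higher number from compound 1 to compound 4 (0.09 log units; within the scatter) is expected to stay within the scatter. Compound 4 is therefore estimated at 1.6 nM, with a range from 0.5 nM to 6 nM.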

Compound 4, half-maximal inhibitory concentration: 1.3 nM
The estimate for compound 4 lay 1.2-fold (0.09 log units) above the measured number; measured number inside the range.
By their numbers in this assay, from the lowest: compounds 1, 4 and 2 (each within the scatter of the next); then compound 3.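

In this assay, cyclopropyl in place of methyl on the shared core gives no change at the digits printed from compound 1 to compound 4 (within the scatter) and is the only measured step at this position among the compounds shown, as the earlier steps all concern the aryl group. The position, an aromatic carbon ortho to a 4-(trifluoromethoxy)phenyl group and two atoms from the ring nitrogen, therefore takes a cyclopropyl group with its 3 heavy atoms and three-membered ring in place of the single carbon of methyl, with no step beyond the scatter on this read-out. Nothing among the available measurements bears on why the number holds across this exchange.

As far as these compounds go, how far this holds at the position stays open, since one exchange gives no limit on size or type of group, and a tert-butyl group, an amine, a methoxy group or a carboxylic acid in the same place could give a different number. Also open, from the compounds shown here alone, is whether the cyclopropyl exchange gives a similar result when the 4-(trifluoromethoxy)phenyl group is replaced by the 4-fluorophenyl group of compound 2 or the 1-methyl-1H-pyrazol-4-yl group of compound 3.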